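Four Close Analogues Held at a Cytotoxicity Ceiling

The source may hold more compounds than are shown below. What is called first, only, known or untested is meant among the compounds shown, and "the series" means these compounds.

Compound 1 `Cn1c(-c2ccc(NC(=O)CN3CCCC3)cc2)nc2cc(C(F)(F)F)ccc21` was examined in an ADME assay on Vero cells (Chlorocebus sabaeus) for cytotoxicity; on this read-out higher numbers stand for lower toxicity in this test and lower numbers for higher toxicity in this test. In this assay compound 1 gives > 100000 nM, which is a limit of the assay and not a number. Compound 2 `O=C(CN1CCCC1)Nc1ccc(-c2nc3cc(C(F)(F)F)ccc3[nH]2)cc1` differs from compound 1 by hydrogen in place of methyl on an aromatic nitrogen. In this assay compound 2 gives > 100000 nM, again a limit. That change is a step that the two limits leave unreadable from compound 1 to compound 2. Compound 3 `Cn1c(-c2ccc(NC(=O)CN3CCCCC3)cc2)nc2cc(C(F)(F)F)ccc21` differs from compound 1 by piperidin-1-yl in place of pyrrolidin-1-yl on a saturated chain carbon bound to a carbonyl carbon. In this assay compound 3 gives > 100000 nM, also a limit. That change is a step that the two limits leave unreadable from compound 1 to compound 3. Compound 4 `O=C(CN1CCCCC1)Nc1ccc(-c2nc3cc(C(F)(F)F)ccc3[nH]2)cc1` differs from compound 3 by hydrogen in place of methyl on an aromatic nitrogen, the same change as that from compound 1 to compound 2, at the same place. Among the compounds with values here, because of the limit of > 100000 nM in this assay, at which 3 of the 3 values shown sit, no step among the three measured compounds can be read. The step from compound 3 to compound 4 is expected to be a step that the limit leaves unreadable from compound 3 to compound 4, resting on (the limit of > 100000 nM in this assay, at which 3 of the 3 values shown sit). Compound 4 is estimated at 150000 nM, expected between 60000 nM and 400000 nM.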

Compound 4, half-maximal cytotoxic concentration: 31000 nM
Estimate against measurement, compound 4: 4.8-fold (0.68 log units) above; the whole stated range lies above it.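

In this assay, hydrogen in place of methyl on the aromatic nitrogen, with piperidin-1-yl on the chain, gives an at least 3.2-fold lower number from compound 3 to compound 4 (0.50 log units; beyond the scatter), and piperidin-1-yl in place of pyrrolidin-1-yl, with hydrogen on that nitrogen, gives an at least 3.2-fold lower number from compound 2 to compound 4 (0.50 log units; beyond the scatter). Going by these compounds, this shows that the change can lower the number in one setting, but not that it carries over to the pyrrolidin-1-yl compounds, since the same change from compound 1 to compound 2 and the other earlier steps cannot be read: the limit of > 100000 nM in this assay, at which 3 of the 4 values shown sit. Both readable steps are lower bounds, so their full size is unknown.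

The compounds shown leave open whether morpholin-4-yl or dimethylamino on the chain would behave like piperidin-1-yl. They also leave open what ethyl on the aromatic nitrogen or a longer chain would do.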